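Removing the Chloro from the Core of Compound 3

This account rests on a few compounds, and the source may have more. Where it says the series, first, only, none or still open, it means among the compounds named here.

Compound 1, `O=C1C(=O)N(CN2CCN(c3ccnc4cc(Cl)ccc34)CC2)c2cccc(Cl)c21`: in an ADME assay on 184B5 cells (Homo sapiens) for cytotoxicity, read by sulforhodamine B assay, with a stated time of 48 h (a higher number here means a weaker inhibitor of growth, a lower number a stronger inhibitor of growth), compound 1 gives 77700 nM.
Compound 2, `NC(=S)N/N=C1/C(=O)N(CN2CCN(c3ccnc4cc(Cl)ccc34)CC2)c2cccc(Cl)c21`: in this assay compound 2 gives 20700 nM.
Compound 3, `NC(=S)N/N=C1/C(=O)N(CN2CCN(c3ccnc4cc(C(F)(F)F)ccc34)CC2)c2cccc(Cl)c21`: in this assay compound 3 gives 87800 nM.

Compound 3 shows the highest number of the three in this assay; its value and that of compound 1 lie within the scatter of each other, while compound 2 gives a lower number, as the step of a 4.2-fold higher number from compound 2 to compound 3 (0.63 log units; beyond the scatter) shows.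

Compound 4, `NC(=S)N/N=C1/C(=O)N(CN2CCN(c3ccnc4cc(C(F)(F)F)ccc34)CC2)c2ccccc21`, differs from compound 3 by one change: hydrogen in place of chloro on an aromatic carbon. Among the measured compounds shown here, the only measured step, a 4.2-fold higher number from compound 2 to compound 3 (0.63 log units; beyond the scatter), concerns the other aromatic system, where trifluoromethyl replaced chloro, and so it does not bear directly on the loss of the chloro from the core. For the measured compounds named here, no pair among the measured compounds differs by a hydrogen in place of chloro on this ring. With no guidance of this kind, the step from compound 3 to compound 4 in this assay is expected to be small, a 1.1-fold higher number from compound 3 to compound 4 (0.06 log units; within the scatter), and not beyond the scatter. The estimate for compound 4 in this assay is therefore 100000 nM, with a range from 35000 nM to 280000 nM.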

Compound 4, concentration for 50% growth inhibition: 20200 nM
Beside the measured number, compound 4's estimate is 5.0-fold (0.69 log units) above it, outside the stated range (below it).
By their numbers in this assay, from the lowest: compounds 4 and 2 (each within the scatter of the next); then compounds 1 and 3 (each within the scatter of the next).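

The chloro on the aromatic carbon of the shared core is not a silent substituent: in this assay, hydrogen in its place gives a 4.3-fold lower number from compound 3 to compound 4 (0.64 log units; beyond the scatter), a move towards stronger inhibition of growth. Among the compounds shown here, until now, the only measured single change lay on the other aromatic system, a 4.2-fold higher number from compound 2 to compound 3 (0.63 log units; beyond the scatter), so the result adds a second place in these compounds where one substitution moves the number beyond the scatter. Nothing available explains why removing this chloro has this effect.

As far as these compounds go, it remains open whether hydrogen in place of chloro would give a similar step in a compound keeping chloro rather than trifluoromethyl on the other aromatic system. From the compounds shown here alone, it is also open how a methoxy group, an amine or a carboxylic acid on this same aromatic carbon would compare with hydrogen and chloro.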